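The source may hold more compounds than are shown below. What is called first, only, known or untested is meant among the compounds shown, and "the series" means these compounds.

Working notes on the series around compound 2.

Compound 2 `CCCS(=O)(=O)Nc1ccc(F)c(C(=O)c2n[nH]c3ncc(-c4cccc(Cl)c4)cc23)c1F` in an assay for binding affinity to dual specificity mitogen-activated protein kinase kinase 4 (Homo sapiens), read by KINOMEscan, tested at 100 nM (on this read-out lower numbers stand for a stronger effect and higher numbers for a weaker effect at the one concentration tested), gives 40%, the highest of the three numbers recorded, which on this read-out is the weakest effect seen. Compound 1 `CCCS(=O)(=O)Nc1ccc(F)c(C(=O)c2n[nH]c3ncc(-c4ccccc4Cl)cc23)c1F` in this assay gives 9.3%; compound 3 `CCCS(=O)(=O)Nc1ccc(F)c(C(=O)c2n[nH]c3ncc(-c4ccc(C)cc4)cc23)c1F` in this assay gives 5.4%. The step of a number 30.7 percentage points higher from compound 1 to compound 2 (beyond the scatter) and the step of a number 34.6 percentage points lower from compound 2 to compound 3 (beyond the scatter) both set compound 2 apart beyond the scatter, while the step of a number 3.9 percentage points lower from compound 1 to compound 3 (within the scatter) stays within it.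

Compound 4 `CCCS(=O)(=O)Nc1ccc(F)c(C(=O)c2n[nH]c3ncc(-c4cccc(OC)c4)cc23)c1F` differs from compound 2 in one place: methoxy in place of chloro on an aromatic carbon. Going by the values given here, no measured step bears directly on this exchange. The two large steps recorded each move the substituent to another carbon of the ring or exchange chloro for methyl together with the position, so neither tells what methoxy in place of chloro does when the position is kept. Among the compounds with values here, the only guide is that compound 2 alone carries a 3-substituted ring and sits highest; a change at that same position may leave the number near that of compound 2 or pull it toward the other two.

Compound 4 is therefore expected to give in this assay about 35%, within 15% to 60%. The expected step of a number 5 percentage points lower from compound 2 to compound 4 (within the scatter) is estimated to be small and not clearly beyond the scatter.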

Compound 4, a percentage reported as activity, at one concentration (the size of the read-out at that concentration, not a potency): 6.3%
Compound 4: the middle estimate sits 28.7 percentage points above what was measured; measured number below the stated range.
By their numbers in this assay, from the lowest: compounds 3, 4 and 1 (each within the scatter of the next); then compound 2.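

With the substituent kept on the same aromatic carbon, methoxy in place of chloro alone gives a number 33.7 percentage points lower from compound 2 to compound 4 (beyond the scatter) in this assay, so a 3-substituted ring does not by itself go with a high number: 3-methoxyphenyl and 3-chlorophenyl are clearly apart. With a number 0.9 percentage points higher from compound 3 to compound 4 (within the scatter) and a number 3 percentage points lower from compound 1 to compound 4 (within the scatter), compound 4 stands with the other two low compounds, leaving compound 2 as the only one of the four set apart beyond the scatter, and at this position the identity of the group matters as well as the carbon it occupies. Nothing at hand accounts for this exchange.

Only chloro and methoxy are shown on this carbon, so it remains open whether the high number of compound 2 is particular to chloro or is shared by other groups there. An amine, a nitrile or an ethoxy group on the same aromatic carbon would show which of these readings holds, and whether the low number of compound 4 extends beyond methoxy.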